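Sulfonamide aryl swap: the step to compound 4

A few compounds are considered here, and "the series" means these few. Any claim that something is new, unique, unknown or untested is made for them only; others in the source may bear on it.

Three aryl sulfonamides sharing one core have been measured in a functional assay on HT-29 cells (Homo sapiens) for antiproliferative activity, read by sulforhodamine B assay, with a stated time of 48 h (a higher number here means a weaker inhibitor, a lower number a stronger inhibitor), so far. Compound 1 `Cc1ccc(NS(=O)(=O)c2ccc(N3CCNC3=O)cc2)cc1C` gives 230 nM and compound 2 `Cc1cc(C)cc(NS(=O)(=O)c2ccc(N3CCNC3=O)cc2)c1` gives 82 nM while compound 3 `O=C1NCCN1c1ccc(S(=O)(=O)Nc2ccc(Cl)cc2)cc1` gives 220 nM on the same read-out. Compound 3 thus sits level with one neighbour and clearly off the other. The two comparisons are a 1.0-fold lower number from compound 1 to compound 3 (0.02 log units; within the scatter) and a 2.7-fold higher number from compound 2 to compound 3 (0.43 log units; beyond the scatter) in this small set.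

The next change gives compound 4 `Cc1ccc(NS(=O)(=O)c2ccc(N3CCNC3=O)cc2)c(C)c1` with 2,4-dimethylphenyl in place of 4-chlorophenyl on a sulfonamide nitrogen, and the counted difference is 2,4-dimethylphenyl in place of 4-chlorophenyl on a sulfonamide nitrogen at that place.

Within the data shown here, no measured compound carries this group, so the steps at the same nitrogen are the only guide. One dimethylphenyl group matched the 4-chlorophenyl group in the first comparison above. Compound 2 goes against that, and the swap between dimethylphenyl groups gave a 2.8-fold lower number from compound 1 to compound 2 (0.45 log units; beyond the scatter) as a modest step. A move towards lower numbers therefore stays possible, but the size of these steps sets its limit. The expected move is a 1.1-fold lower number from compound 3 to compound 4 (0.04 log units; within the scatter) and so no step beyond the scatter. In this assay the estimate for compound 4 is 200 nM with a range from 70 nM to 600 nM expected.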

Compound 4, half-maximal inhibitory concentration: 180 nM
Compound 4: middle estimate off by 1.1-fold (0.05 log units), on the high side, within the range that was stated.
By their numbers in this assay, from the lowest: compound 2; then compounds 4, 3 and 1 (each within the scatter of the next).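

Compound 4 adds a third dimethylphenyl group on a sulfonamide nitrogen, and in this assay it falls in with the 4-chlorophenyl and 3,4-dimethylphenyl compounds (a 1.2-fold lower number from compound 3 to compound 4 (0.09 log units; within the scatter); a 1.3-fold lower number from compound 1 to compound 4 (0.11 log units; within the scatter)). The 3,5-dimethylphenyl group of compound 2 now stands apart from every other aryl group shown, including a second dimethylphenyl isomer (a 2.2-fold higher number from compound 2 to compound 4 (0.34 log units; beyond the scatter)), so carrying methyl groups on this aryl ring does not alone set the number: compounds 1 and 4 carry them too and stay level with the chlorinated compound 3, while compound 2 gives the lowest number of the four. Nothing available on these compounds explains why the 3,5-dimethylphenyl group stands apart.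

On these data alone, whether the lower number of compound 2 is particular to its methyl groups remains open, since a 3,5-dichlorophenyl or 3,5-dimethoxyphenyl group on the same nitrogen would separate that arrangement from the identity of the groups. As far as these compounds go, how far this nitrogen accepts anything other than a simple substituted phenyl, such as an aryl group bearing an amine or a carboxylic acid, or a longer alkyl chain, also remains open.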